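Two Benzyl Swaps on One Core and Cell Toxicity

The compounds below may be only part of what the source reports. "The series", "measured", "known", "first", "only" and "open" are said of these compounds alone.

Of the compounds shown here, three have been measured in an ADME assay on HepG2 cells (Homo sapiens) for cytotoxicity, read by luminescence, CellTiter-Glo and ATP content, with a stated time of 72 h; on this read-out lower numbers stand for an effect already at smaller amounts and higher numbers for an effect only at larger amounts of compound. Compound 1 `COc1cccc(CNCCCNc2ccnc3cc(Cc4cccc(C(F)(F)F)c4)ccc23)c1O` gives 1720 nM, compound 2 `COc1cccc(CNCCCNc2ccnc3cc(Cc4ccc(C#N)cc4)ccc23)c1O` gives 7150 nM, and compound 3 `N#Cc1ccc(Cc2ccc3c(NCCCNCc4ccco4)ccnc3c2)cc1` gives 7910 nM. Compound 2 and compound 3 differ in furan-2-yl in place of 2-hydroxy-3-methoxyphenyl on a saturated chain carbon bound to an amine nitrogen, giving a 1.1-fold higher number from compound 2 to compound 3 (0.04 log units; within the scatter). Compound 2 and compound 1 differ in 3-(trifluoromethyl)phenyl in place of 4-cyanophenyl on a saturated chain carbon bound to an aromatic carbon, giving a 4.2-fold lower number from compound 2 to compound 1 (0.62 log units; beyond the scatter). Within the data shown here, compound 4 `FC(F)(F)c1cccc(Cc2ccc3c(NCCCNCc4ccco4)ccnc3c2)c1` is not yet measured; it differs from compound 3 by 3-(trifluoromethyl)phenyl in place of 4-cyanophenyl on a saturated chain carbon bound to an aromatic carbon, the same change at the same place as the one seen between compound 2 and compound 1. Among the measured compounds shown here, compound 4 is therefore expected to show a 4.2-fold lower number from compound 3 to compound 4 (0.62 log units; beyond the scatter), about the size of the earlier step, because a 4.2-fold lower number from compound 2 to compound 1 (0.62 log units; beyond the scatter) is the only measured instance of this change. The estimate for compound 4 in this assay is 1900 nM, with a range from 900 nM to 4500 nM.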

Compound 4, half-maximal effective concentration: 3190 nM
The estimate for compound 4 lay 1.7-fold (0.23 log units) below the measured number, within the range that was stated.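

In this assay, putting 3-(trifluoromethyl)phenyl in place of 4-cyanophenyl on the core carrying furan-2-yl gives a 2.5-fold lower number from compound 3 to compound 4 (0.39 log units; beyond the scatter), and the two instances of this change agree: the same change on two cores in this assay, a 4.2-fold lower number (0.62 log units; beyond the scatter) from compound 2 to compound 1 and a 2.5-fold lower number (0.39 log units; beyond the scatter) from compound 3 to compound 4, 1.7-fold (0.22 log units) apart, within the scatter of two such steps. Putting furan-2-yl in place of 2-hydroxy-3-methoxyphenyl gives a 1.9-fold higher number from compound 1 to compound 4 (0.27 log units; within the scatter), and this change also reads alike in both instances: the same change on two cores in this assay, a 1.1-fold higher number (0.04 log units; within the scatter) from compound 2 to compound 3 and a 1.9-fold higher number (0.27 log units; within the scatter) from compound 1 to compound 4, 1.7-fold (0.22 log units) apart, within the scatter of two such steps. These two pairs show that both changes carried over within this small set, but they do not show that either would carry over to other cores, and they do not explain the shifts.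

From the compounds shown here alone, it remains open whether a phenyl ring bearing a carboxylic acid or an amine would behave like 3-(trifluoromethyl)phenyl at the same place. Going by these compounds, the effect of a longer chain between the two nitrogens also remains open.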